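Aryl ester substituent change on the core of compound 1

The source may report more compounds than this note shows. Statements on the series, on what has been measured and on what is new or still open speak of the compounds shown alone.

For the measured compounds named here, compound 1 `C=CC(=C)CC[C@@H]1[C@@]2(C)CCC[C@](C)(COC(=O)/C=C\c3ccc(O)cc3)[C@@H]2CC[C@@]1(C)O` is the only member of the series with a numerical value in a functional assay on SW480 cells (Homo sapiens) for cytotoxicity, read by MTT assay, with a stated time of 48 h; a lower number here means a stronger inhibitor, a higher number a weaker inhibitor: in this assay compound 1 gives 13600 nM. Compound 2 `C=C1CC[C@@H]2[C@](C)(CCC[C@]2(C)C(=O)O)[C@H]1CC/C(C)=C/CO` stands only at a limit of the assay, > 40000 nM. Going by the values given here, that second value therefore sits at the limit of > 40000 nM in this assay, at which 1 of the 2 values shown sits, and no step between measured compounds can be drawn from the pair. Compound 3 `C=CC(=C)CC[C@@H]1[C@@]2(C)CCC[C@](C)(COC(=O)/C=C/c3ccc(O)c(OC)c3)[C@@H]2CC[C@@]1(C)O` keeps the core of compound 1 and differs only in the ester portion: 2-(4-hydroxy-3-methoxyphenyl)ethenyl in place of 2-(4-hydroxyphenyl)ethenyl on a carbonyl carbon. Among the compounds with values here, no measured step speaks to a change of this kind, so the step from compound 1 to compound 3 in this assay is expected to be small, none beyond the usual scatter. The estimated step is a 1.1-fold lower number from compound 1 to compound 3 (0.05 log units; within the scatter). Compound 3 is expected to give about 12000 nM in this assay, with a plausible range from 5000 nM to 30000 nM.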

Compound 3, half-maximal inhibitory concentration: 16900 nM
Estimate against measurement, compound 3: 1.4-fold (0.15 log units) below; the range from low to high includes it.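

For the compounds shown here, the first measured step at this position is small: in this assay, 2-(4-hydroxy-3-methoxyphenyl)ethenyl in place of 2-(4-hydroxyphenyl)ethenyl on a carbonyl carbon gives a 1.2-fold higher number from compound 1 to compound 3 (0.09 log units; within the scatter). The ester portion therefore accepts this larger group, with 11 heavy atoms against 9 and one more hydrogen-bond acceptor, while the two compounds stay within the scatter of each other. No measured property in the series bears on the size of this step.

Going by these compounds, whether the position stays this flat in this assay under a larger departure remains open, for example with an amine or a carboxylic acid on the aromatic ring, or a longer chain in place of the ethenyl. A single step also leaves open whether the same change would read alike on another core.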